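This account rests on a few compounds, and the source may have more. Where it says the series, first, only, none or still open, it means among the compounds named here.

In a functional assay on HeLa cells (Homo sapiens) for cytotoxicity, read by MTT assay, with a stated time of 72 h (on this read-out lower numbers stand for stronger inhibition and higher numbers for weaker inhibition), compound 1 (`CCOC(=O)c1csc2nc(-c3cccc(NC(=O)c4ccco4)c3)cn12`) gives > 20000 nM, which is a limit of the assay and not a number. Compound 2 (`CCOC(=O)c1csc2nc(-c3ccc(NC(=O)Nc4ccc(Br)cn4)cc3)cn12`) gives > 20000 nM, also a limit. Compound 3 (`CCOC(=O)c1csc2nc(-c3ccc(NC(=O)Nc4ccccc4)cc3)cn12`) gives > 20000 nM, again a limit. Compound 4 (`CCOC(=O)c1csc2nc(-c3cccc(NC(=O)CCl)c3)cn12`) keeps the core of compound 1 but carries chloromethyl in place of furan-2-yl on a carbonyl carbon. For the measured compounds named here, the only measured step, a step that the two limits leave unreadable from compound 2 to compound 3, concerns a different change and has no readable size. The remaining evidence is the limit of > 20000 nM in this assay, at which 3 of the 3 values shown sit. In this assay, only a modest move toward stronger inhibition is therefore expected, and none may be seen. The expected step is an at least 1.4-fold lower number from compound 1 to compound 4 (0.15 log units; that floor lies within the scatter). Compound 4 is estimated at 14000 nM, with an expected range of 4000 nM to 20000 nM.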

Compound 4, half-maximal inhibitory concentration: 20000 nM
For compound 4 the middle estimate is 1.4-fold (0.15 log units) below the measured one; low and high end bracket the measured number.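

In this assay, chloromethyl in place of furan-2-yl on a carbonyl carbon gives a number no higher from compound 1 to compound 4 (the limit leaves the size open). For the compounds shown here, compound 4 gives 20000 nM, the only value shown that is a number and not a limit. Compound 1 gives > 20000 nM, which is a limit of the assay, so this position has now yielded one number, but no size for the change.

The size of this step cannot be read, and most of the values shown stay at the limit: the limit of > 20000 nM in this assay, at which 3 of the 4 values shown sit. On these data alone, whether an amine or a longer chain in place of chloromethyl on this carbonyl carbon would give a lower number remains open.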